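The source may report more compounds than this note shows. Statements on the series, on what has been measured and on what is new or still open speak of the compounds shown alone.

Measured so far in a functional assay on DU-145 cells (Homo sapiens) for antiproliferative activity, read by MTT assay, with a stated time of 24 h; on this read-out higher numbers stand for weaker inhibition and lower numbers for stronger inhibition: compound 1 `COc1cc(-c2cc(C(=O)/C=C/c3ccc(Cl)cc3)nc3cc(-c4ccccc4)nn23)cc(OC)c1OC` with 19500 nM, and compound 2 `COc1cc(-c2cc(C(=O)/C=C/c3ccccc3)nc3cc(-c4ccccc4)nn23)cc(OC)c1OC` with 16300 nM.

Compound 2 and compound 1 share one core and differ only on the aromatic ring at the end of the chain; their two numbers lie within the scatter of each other, as the step of a 1.2-fold lower number from compound 1 to compound 2 (0.08 log units; within the scatter) shows, so neither stands apart from the other in this assay.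

Compound 3 `COc1ccc(/C=C/C(=O)c2cc(-c3cc(OC)c(OC)c(OC)c3)n3nc(-c4ccccc4)cc3n2)cc1OC` takes the next step from compound 2: 3,4-dimethoxyphenyl in place of phenyl on a double-bonded chain carbon bound to a double-bonded chain carbon. For the measured compounds named here, no measured step tells how this assay answers such a change; the one step in hand, from chloro to hydrogen on the same ring, was a 1.2-fold lower number from compound 1 to compound 2 (0.08 log units; within the scatter) and stayed within the scatter. On that ground a step of similar size is expected, a 1.4-fold lower number from compound 2 to compound 3 (0.13 log units; within the scatter), with no firm direction. Compound 3 is therefore estimated at 12000 nM, between 4000 nM and 35000 nM.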

Compound 3, half-maximal inhibitory concentration: 15300 nM
Estimate against measurement, compound 3: 1.3-fold (0.11 log units) below; low and high end bracket the measured number.
By their numbers in this assay, from the lowest: compounds 3, 2 and 1 (each within the scatter of the next).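

In this assay, 3,4-dimethoxyphenyl in place of phenyl gives a 1.1-fold lower number from compound 2 to compound 3 (0.03 log units; within the scatter) and 3,4-dimethoxyphenyl in place of 4-chlorophenyl gives a 1.3-fold lower number from compound 1 to compound 3 (0.11 log units; within the scatter) at this same place on the chain. The earlier pair covered only the swap of chloro for hydrogen, whereas this change brings in oxygen atoms and a larger group, and still the assay does not separate the three compounds. Nothing at hand offers a reason for this flat reading.

From the compounds shown here alone, it remains open whether any group at this place can move the number beyond the scatter, such as a ring carrying an amine or a carboxylic acid, or a longer chain in place of the ethenyl link. The compounds shown also leave open how the assay answers changes elsewhere on the shared core.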